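A few compounds are considered here, and "the series" means these few. Any claim that something is new, unique, unknown or untested is made for them only; others in the source may bear on it.

Measured in a functional assay on MCF7 cells (Homo sapiens) for inhibition, read by CCK-8 assay, with a stated time of 48 h; a higher number here means a weaker inhibitor of growth, a lower number a stronger inhibitor of growth:
- Compound 1 `Cc1ccccc1Nc1nc(NCc2ccco2)ncc1Cl`: > 100000 nM
- Compound 2 `Cc1ccccc1Nc1nc(Nc2ccc(N3CCN(C)CC3)cc2)ncc1Cl`: 20600 nM
- Compound 3 `Cc1ccc(CNc2nc(Nc3ccc(N4CCN(C)CC4)cn3)ncc2Cl)cc1`: 38100 nM

For the measured compounds named here, only two of these readings are true numbers. In this assay, compound 3 gives 38100 nM, and this lies within the usual scatter of compound 2 at 20600 nM. The two therefore cannot be told apart here.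

Compound 1 reads > 100000 nM, which is a limit of the assay and not a number.

Compound 4 `CN1CCN(c2ccc(Nc3ncc(Cl)c(NCc4ccco4)n3)nc2)CC1` has not yet been measured. It keeps the structure of compound 3 except for one change: furan-2-yl in place of 4-methylphenyl on a saturated chain carbon bound to a nitrogen on an aromatic ring.

Going by the values given here, no measured pair shows this change on its own. Among the compounds with values here, the only hint comes from compound 1, which also carries a furan-2-yl group and reads > 100000 nM, a limit. However, compound 1 differs from compound 4 in more than one place, so it supports only a slight lean towards a higher number. The expected change is a 1.2-fold higher number from compound 3 to compound 4 (0.07 log units; within the scatter), which would be no step beyond the scatter. In this assay, the estimate for compound 4 is 45000 nM, with an expected range from 18000 nM to 100000 nM.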

Compound 4, concentration for 50% growth inhibition: 21300 nM
Compound 4: middle estimate off by 2.1-fold (0.32 log units), on the high side; the measured number falls inside the stated range.
By their numbers in this assay, from the lowest: compounds 2, 4 and 3 (each within the scatter of the next). At a limit, above all of these: compound 1.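

Swapping 4-methylphenyl for furan-2-yl on a saturated chain carbon bound to a nitrogen on an aromatic ring gives the first single-change step in this assay, and it is a 1.8-fold lower number from compound 3 to compound 4 (0.25 log units; within the scatter). At this place, then, a six-membered aromatic ring of carbon only and a five-membered aromatic ring with one hetero atom cannot be told apart, even though the entering group has fewer heavy atoms and carries a hydrogen-bond acceptor that the leaving group lacks. The reading of compound 4 is a true number, whereas the only limit in the set belongs to compound 1: the limit of > 100000 nM in this assay, at which 1 of the 4 values shown sits.

Both groups compared here are aromatic rings, so the compounds shown leave open whether a saturated ring such as cyclohexyl, or an amine at the end of a longer chain, would read any differently at this place. They also leave open whether the same swap would give a similar step with a different group elsewhere on the shared core, as it appears in a single pair only.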